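The compounds below may be only part of what the source reports. "The series", "measured", "known", "first", "only" and "open" are said of these compounds alone.

In a functional assay on HL-60 cells (Homo sapiens) for cytotoxicity, read by MTT assay, with a stated time of 72 h (a lower number here means a stronger inhibitor, a higher number a weaker inhibitor), compound 1 (`Oc1ccc(CC[C@@H](O)C[C@H](O)CCc2ccc(O)c(O)c2)cc1O`) gives 1.8 ug/mL and compound 2 (`OC[C@H]1O[C@@H](O[C@H](CCc2ccc(O)c(O)c2)C[C@H](O)CCc2ccc(O)cc2)[C@H](O)[C@@H](O)[C@@H]1O`) gives 6.2 ug/mL as the higher of the two numbers, a gap beyond the usual scatter. Compound 3 (`OC[C@H]1O[C@@H](O[C@H](CCc2ccc(O)c(O)c2)C[C@H](O)CCc2ccc(O)c(O)c2)[C@H](O)[C@@H](O)[C@@H]1O`) differs from compound 2 by one change (hydroxy in place of hydrogen on an aromatic carbon), hydroxy in place of hydrogen on an aromatic carbon, which turns 4-hydroxyphenyl into 3,4-dihydroxyphenyl. Compound 1 also carries 3,4-dihydroxyphenyl there and gives 1.8 ug/mL while differing elsewhere too, so a small expected step toward a lower number in this assay (a 1.6-fold lower number from compound 2 to compound 3 (0.21 log units; within the scatter)) may stay within the scatter. For compound 3 the estimate is 3.8 ug/mL within an expected range of 1.8 ug/mL to 8 ug/mL for this measurement.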

Compound 3, half-maximal inhibitory concentration: 3 ug/mL
The estimate for compound 3 lay 1.3-fold (0.10 log units) above the measured number; measured number inside the range.
By their numbers in this assay, from the lowest: compounds 1 and 3 (each within the scatter of the next); then compound 2.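

In this assay, going from 4-hydroxyphenyl to 3,4-dihydroxyphenyl gives a 2.1-fold lower number from compound 2 to compound 3 (0.32 log units; beyond the scatter), a modest step, so this added hydroxy group has a small but readable effect on the number. Placing 3,4,5-trihydroxy-6-(hydroxymethyl)oxan-2-yl in place of hydrogen on an oxygen on a saturated carbon gives a 1.7-fold higher number from compound 1 to compound 3 (0.22 log units; within the scatter), so compound 1 and compound 3 cannot be told apart here. Nothing shown gives a reason for either result. Whether the hydroxy group itself is needed remains open, since the compounds shown do not include a methoxy group or a fluorine atom at that place.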